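Carboxymethyl Replaces Trifluoromethyl on the Aryl Imine

This account rests on a few compounds, and the source may have more. Where it says the series, first, only, none or still open, it means among the compounds named here.

Of the compounds shown here, three sharing one core have been measured in a functional assay on the whole organism with Rattus norvegicus as the target; a higher number here means that more compound is needed for the effect, a lower number that less compound is needed. Compound 1 `CC1CCC(/C=N/c2ccc(F)cc2)=C2NC=C(C(=O)O)C(=O)N21` carries fluoro on the aromatic ring and gives 10.6 umol/kg in this assay. Compound 2 `CCOc1ccc(/N=C/C2=C3NC=C(C(=O)O)C(=O)N3C(C)CC2)cc1` carries ethoxy at the same place and gives 8.96 umol/kg. The step of a 1.2-fold lower number from compound 1 to compound 2 (0.07 log units; within the scatter) lies within the scatter. Compound 3 `CC1CCC(/C=N/c2ccc(C(F)(F)F)cc2)=C2NC=C(C(=O)O)C(=O)N21` carries trifluoromethyl; in this assay compound 3 is reported only as a limit, > 100 umol/kg, not as a number. Compound 3 thus sits at the limit (the limit of > 100 umol/kg in this assay, at which 1 of the 3 values shown sits), the weakest position among the three. The steps of an at least 9.4-fold higher number from compound 1 to compound 3 (0.97 log units; beyond the scatter) and an at least 11-fold higher number from compound 2 to compound 3 (1.04 log units; beyond the scatter) are both beyond the scatter.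

Compound 4 `CC1CCC(/C=N/c2ccc(CC(=O)O)cc2)=C2NC=C(C(=O)O)C(=O)N21` is not yet measured. It differs from compound 3 in one place: carboxymethyl in place of trifluoromethyl on an aromatic carbon. For the measured compounds named here, the steps that bear on this change are those from fluoro and ethoxy to trifluoromethyl, both beyond the scatter. Going by the values given here, no measured step covers carboxymethyl itself, so its result is open. Because compound 1 gives 10.6 umol/kg and compound 2 gives 8.96 umol/kg with differing groups at this position, compound 4 is expected to return toward the numbers of those two, though with wide uncertainty. Only compound 3, with trifluoromethyl, is reported as a limit. The estimated step of an at least 3.3-fold lower number from compound 3 to compound 4 (0.52 log units; beyond the scatter) is expected to be a lower number. The estimate for compound 4 in this assay is 30 umol/kg, within a range from 8 umol/kg to 150 umol/kg.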

Compound 4, dose for 50% inhibition: 5.8 umol/kg
For compound 4 the middle estimate is 5.2-fold (0.71 log units) above the measured one; the whole stated range lies above it.
By their numbers in this assay, from the lowest: compounds 4, 2 and 1 (each within the scatter of the next). At a limit, above all of these: compound 3.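

In this assay, carboxymethyl in place of trifluoromethyl gives an at least 17-fold lower number from compound 3 to compound 4 (1.23 log units; beyond the scatter), so the loss seen with trifluoromethyl on this aromatic carbon, para to a large group, does not extend to a group of the same heavy-atom count that carries a hydrogen-bond donor and a hydrogen-bond acceptor. Carboxymethyl also cannot be told apart from the two earlier groups: in place of ethoxy it gives a 1.5-fold lower number from compound 2 to compound 4 (0.19 log units; within the scatter), and in place of fluoro it gives a 1.8-fold lower number from compound 1 to compound 4 (0.26 log units; within the scatter), so three different groups now stand together within the scatter. Compound 3, with trifluoromethyl, is the one compound set apart, and it is reported only as a limit: the limit of > 100 umol/kg in this assay, at which 1 of the 4 values shown sits.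

The four compounds do not show why trifluoromethyl alone stands apart, and a limit cannot tell how far compound 3 lies from the others. On these data alone, whether an amine, a carboxylic acid set directly on the aromatic ring, or a longer chain ending in a carboxylic acid would stay with compound 1, compound 2 and compound 4 or fall away like compound 3 remains open.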